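Swapping Pyridin-3-yl for Ethyl at the Carbonyl

The source may hold more compounds than are shown below. What is called first, only, known or untested is meant among the compounds shown, and "the series" means these compounds.

Compound 1 `CC(=O)N1CCC(C(=O)N2N=CCC2c2ccccc2)CC1`: 2.5
Compound 2 `O=C(c1cccnc1)N1CCC(C(=O)N2N=CCC2c2ccccc2)CC1`: 2.6

Going by the values given here, in a physicochemical assay for lipophilicity, read by HPLC, measured as chromatographic lipophilicity, at pH 7.4 (on this read-out lower numbers stand for lower lipophilicity and higher numbers for higher lipophilicity), compound 2 stands level with compound 1, the only other compound measured so far. The gap between them is a number 0.10 log units higher from compound 1 to compound 2 (within the scatter).

The next compound to be measured is compound 3 `CCC(=O)N1CCC(C(=O)N2N=CCC2c2ccccc2)CC1`. It differs from compound 2 by a single swap: ethyl in place of pyridin-3-yl on a carbonyl carbon. Put simply, this is ethyl in place of pyridin-3-yl on a carbonyl carbon.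

Among the compounds with values here, only one measured step bears on this swap. It changes the same place, putting pyridin-3-yl in place of methyl on a carbonyl carbon, and its size was a number 0.10 log units higher from compound 1 to compound 2 (within the scatter). Compound 3 goes back the other way, with ethyl where compound 1 has methyl. Within the data shown here, no measured step goes from methyl to ethyl, so that part remains open. A small upward step in this assay is expected, though none beyond the scatter, and this lean is a judgement rather than a measurement.

The estimated change is a number 0.20 log units higher from compound 2 to compound 3 (within the scatter).

For compound 3 the expected value is 2.8, with an estimated range from 2.5 to 3.1.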

Compound 3, distribution coefficient: 3.2
Estimate against measurement, compound 3: 0.40 log units below; measured number outside the range, above it.
By their numbers in this assay, from the lowest: compounds 1 and 2 (each within the scatter of the next); then compound 3.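

At this position, on a carbonyl carbon whose other neighbour is an amide-type nitrogen in a ring, this assay does separate the groups: ethyl in place of pyridin-3-yl gives a number 0.60 log units higher from compound 2 to compound 3 (beyond the scatter) and so stands clearly apart from the aromatic ring. A very small edit has the larger effect here. Methyl in place of hydrogen on a saturated chain carbon bound to a carbonyl carbon gives a number 0.70 log units higher from compound 1 to compound 3 (beyond the scatter) while the far bigger swap from methyl to pyridin-3-yl gives only a number 0.10 log units higher from compound 1 to compound 2 (within the scatter), and the number of heavy atoms in the group does not sort these three compounds. No measurement at hand offers a reason for this difference between ethyl and pyridin-3-yl.

Three compounds cannot show whether the number keeps climbing with a longer chain such as propyl or butyl, or levels off after ethyl. Also open, on these data alone, is how a group of another kind on the same carbonyl carbon, such as an amine, a carboxylic acid or a phenyl ring, would read in this assay when set against these three.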